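The source may report more compounds than this note shows. Statements on the series, on what has been measured and on what is new or still open speak of the compounds shown alone.

Compound 1, `CC(C)n1ncc2c(C(=O)NCc3cn(-c4cccc(Br)c4)nn3)cccc21`, gives > 40000 nM in a functional assay on HepG2 cells (Homo sapiens) for inhibition, read by MTT assay, with a stated time of 72 h (on this read-out lower numbers stand for stronger inhibition and higher numbers for weaker inhibition), a limit of the assay rather than a number.
Compound 2, `CC(C)n1ncc2c(C(=O)NCc3cn(-c4cccc(F)c4)nn3)cccc21`, gives > 40000 nM in this assay, again a limit of the assay.

Among the measured compounds shown here, compound 2 thus stands on a limit in this assay, and the only other value shown sits on the same limit (the limit of > 40000 nM in this assay, at which 2 of the 2 values shown sit). Compound 3, `CC(C)n1ncc2c(C(=O)NCc3cn(-c4ccc(C(F)(F)F)cc4)nn3)cccc21`, differs from compound 2 in one place: 4-(trifluoromethyl)phenyl in place of 3-fluorophenyl on an aromatic nitrogen. For the measured compounds named here, the single measured step, a step that the two limits leave unreadable from compound 1 to compound 2, runs between two limits and so gives no readable size for a change of the group on that aromatic nitrogen. Going by the values given here, no measured step bears directly on a trifluoromethyl group in this position. With both measured compounds at the limit, the expected step is a step that the limit leaves unreadable from compound 2 to compound 3, that is, no movement beyond the scatter that the data could show, and a limit is the most likely report. Compound 3 is therefore estimated at 50000 nM, with a range from 20000 nM to 150000 nM.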

Compound 3, half-maximal inhibitory concentration: > 40000 nM
Compound 3: no number, only a limit (the forecaster's own chance of this, stated with the estimate: 80%); the middle value is on the limit's open side.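

Compound 3 also gives only a limit, so neither the step from compound 1 to compound 3 nor the step from compound 2 to compound 3 can be read: the limit of > 40000 nM in this assay, at which 3 of the 3 values shown sit. The compounds shown leave open whether any group on that aromatic nitrogen gives a measurable number in this assay at all.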